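A Double Bond Redrawn at the Assay Limit

The source may hold more compounds than are shown below. What is called first, only, known or untested is meant among the compounds shown, and "the series" means these compounds.

In a functional assay on HL-60 cells (Homo sapiens) for cytotoxicity (on this read-out lower numbers stand for stronger inhibition and higher numbers for weaker inhibition), compound 1 `CC1(C)CCC(C)(C)c2cc(/C=C/c3cccc(N)c3)ccc21` gives 20000 nM. Compound 2 `C/C(=C\c1cccc(C(=O)O)c1)c1ccc2c(c1)C(C)(C)CCC2(C)C` returns only a limit of the assay, > 100000 nM, and no number. Compound 3 `C/C(=C/c1cccc(C(=O)O)c1)c1ccc2c(c1)C(C)(C)CCC2(C)C` has the same atoms and bonds as compound 2 and differs only in configuration as drawn: the two compounds have the same atoms and bonds and differ only in configuration as drawn: 1 of 1 stereo elements differ; a double bond is drawn E in compound 2 and Z in compound 3, a double bond drawn E in compound 2 and Z in compound 3. No step beyond the scatter is expected in this assay, and the estimated change is an at least 1.2-fold lower number from compound 2 to compound 3 (0.09 log units; that floor lies within the scatter). For compound 3 the expected value is 80000 nM, with an estimated range of 25000 nM to 150000 nM.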

Compound 3, half-maximal inhibitory concentration: 50000 nM
For compound 3 the middle estimate is 1.6-fold (0.20 log units) above the measured one; the measured number falls inside the stated range.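

Turning the double bond from E to Z gives the first reading of configuration in this series, since in this assay the change amounts to an at least 2.0-fold lower number from compound 2 to compound 3 (0.30 log units; that floor lies within the scatter). For compound 2 the value > 100000 nM is a limit of the assay and not a number, so only a floor can be given for the step: the limit of > 100000 nM in this assay, at which 1 of the 3 values shown sits. Any difference between the two can be traced to the double bond alone: the fact that compounds 2 and 3 differ only in the configuration as drawn

As far as these compounds go, how large the step really is remains open. So does whether an ester or a primary amide in place of the carboxylic acid would respond to the same change.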